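The source may report more compounds than this note shows. Statements on the series, on what has been measured and on what is new or still open speak of the compounds shown alone.

Measured in a physicochemical assay for solubility, in phosphate buffer, with a stated time of 24 h, at pH 7.4, tested at 100 uM; on this read-out higher numbers stand for higher solubility and lower numbers for lower solubility:
- Compound 1 `O=C(NCc1ccc(S(=O)(=O)c2ccccc2)cc1)c1cc2cnccc2[nH]1`: 3000 nM
- Compound 2 `O=C(NCc1ccc(S(=O)(=O)c2ccccc2)cc1)N1Cc2ccncc2C1`: 115000 nM

Compound 2 has the higher of these two numbers. Compound 3 `O=C(NCc1ccc(S(=O)(=O)c2cncc(C(F)(F)F)c2)cc1)N1Cc2ccncc2C1` differs from it in one place: 5-(trifluoromethyl)pyridin-3-yl in place of phenyl on a sulfonyl sulfur. In words, 5-(trifluoromethyl)pyridin-3-yl stands in place of phenyl on a sulfonyl sulfur. Going by the values given here, the only measured step, a 38-fold higher number from compound 1 to compound 2 (1.58 log units; beyond the scatter), was large, but it changed a different group, on a carbonyl carbon, so it offers no direct guide here. With little to go on, the expected change is a modest drop, a 2.3-fold lower number from compound 2 to compound 3 (0.36 log units; beyond the scatter). For compound 3 the estimated value is 50000 nM, with an expected range of 12000 nM to 130000 nM.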

Compound 3, solubility: 83000 nM
Estimate against measurement, compound 3: 1.7-fold (0.22 log units) below, and the stated range covers the measured number.
By their numbers in this assay, from the lowest: compound 1; then compounds 3 and 2 (each within the scatter of the next).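

In this assay, the group on a sulfonyl sulfur gets its first test here: 5-(trifluoromethyl)pyridin-3-yl in place of phenyl gives a 1.4-fold lower number from compound 2 to compound 3 (0.14 log units; within the scatter). Thus a swap of phenyl for a group with more heavy atoms and a hydrogen-bond acceptor leaves two numbers that cannot be told apart, a result the earlier step on a carbonyl carbon could not show. No supporting measurement accounts for this result. Trifluoromethyl and the ring nitrogen enter together, so their separate contributions remain open. Also open, on these data alone, is how an amine or a carboxylic acid in place of phenyl on that sulfonyl sulfur would read.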